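Aryl swap on the shared core: compound 3 to compound 4

The source may report more compounds than this note shows. Statements on the series, on what has been measured and on what is new or still open speak of the compounds shown alone.

Measured so far in an in vitro functional assay on HEK285-7 cells for antagonist activity at prostaglandin D2 receptor 2 (Homo sapiens), read by BRET and beta-arrestin recruitment; a higher number here means a larger maximal response, a lower number a smaller maximal response:
compound 1, `O=C(O)Cc1sc(C(c2ccc(F)cc2)c2ccc(F)cc2)nc1-c1ccnc(N2CCCC2)c1`, 80%
compound 2, `N#Cc1ccc(-c2nc(C(c3ccc(F)cc3)c3ccc(F)cc3)sc2CC(=O)O)cc1`, 30%
compound 3, `O=C(O)Cc1sc(C(c2ccc(F)cc2)c2ccc(F)cc2)nc1-c1ccnc(Cl)c1`, 80%

Compound 3 stands level with compound 1 at the digits given, the two of them together the highest of the three numbers; the step of no change at the digits printed from compound 1 to compound 3 (within the scatter) lies within the scatter, so no order between them is claimed. Compound 2 lies well below both, the step of a number 50 percentage points higher from compound 2 to compound 3 (beyond the scatter) being large.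

Compound 4, `O=C(O)Cc1sc(C(c2ccc(F)cc2)c2ccc(F)cc2)nc1-c1cccc(F)c1`, is not yet measured. It differs from compound 3 in one place: 3-fluorophenyl in place of 2-chloropyridin-4-yl on an aromatic carbon. The entering group, like 4-cyanophenyl in compound 2, is a six-membered aromatic ring of carbon only with no hydrogen-bond acceptor, whereas the leaving group carries one.

For the measured compounds named here, the steps that bear on this are a number 50 percentage points lower from compound 1 to compound 2 (beyond the scatter) and a number 50 percentage points higher from compound 2 to compound 3 (beyond the scatter), both large, which show that swapping the pyridine-type arm for a carbon-only ring can cut the maximal response sharply, and no change at the digits printed from compound 1 to compound 3 (within the scatter), which shows that the substituent on that arm changed nothing. Whether a fluorine behaves like a nitrile here is not known from these three compounds, so the estimate is wide.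

Compound 4 is expected to lie lower in this assay, at about 55%, with a step of a number 25 percentage points lower from compound 3 to compound 4 (beyond the scatter), the range 30% to 80%.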

Compound 4, largest response reached (reported as efficacy), in percent of the reference or control that the assay uses: 80%
Compound 4: the middle estimate sits 25 percentage points below what was measured; low and high end bracket the measured number.
By their numbers in this assay, from the lowest: compound 2; then compounds 1, 3 and 4 (each within the scatter of the next).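

In this assay, 3-fluorophenyl at this position, on an aromatic carbon of the five-membered aromatic ring, gives no change at the digits printed from compound 3 to compound 4 (within the scatter) and no change at the digits printed from compound 1 to compound 4 (within the scatter), so among these compounds an arm of carbon only with no hydrogen-bond acceptor holds the same maximal response as the two pyridine arms, and the pyridine nitrogen is not needed for it. The change between the two carbon-only arms gives a number 50 percentage points higher from compound 2 to compound 4 (beyond the scatter), which removes the earlier reading of a pyridine-to-carbon-ring swap as what lowers the number and leaves compound 2, with its 4-cyanophenyl, as the only one of the four that goes against a flat response at this position. Nothing measured here accounts for the gap between the 4-cyanophenyl and 3-fluorophenyl arms.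

Still open, from the compounds shown here alone, is whether that gap goes with the nitrile or with where the substituent sits on the ring, a question that 4-fluorophenyl and 3-cyanophenyl arms would separate. Also open, going by these compounds, is whether plain phenyl, or a phenyl ring carrying an amine or a carboxylic acid, stays with the higher group or falls towards compound 2.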